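Taking the amino group off compound 2

A few compounds are considered here, and "the series" means these few. Any claim that something is new, unique, unknown or untested is made for them only; others in the source may bear on it.

- compound 1 `C=C1[C@H](n2cnc3c(Cl)nc(N)nc32)O[C@H](CO)[C@H]1O`: 10000 nM
- compound 2 `C=C1[C@H](n2cnc3c(O)nc(N)nc32)O[C@H](CO)[C@H]1O`: 8500 nM
- compound 3 `C=C1[C@H](n2cnc3c(SC)nc(N)nc32)O[C@H](CO)[C@H]1O`: > 500000 nM (a limit)

In a functional assay on L1210 cells (Mus musculus) for inhibition (on this read-out lower numbers stand for stronger inhibition and higher numbers for weaker inhibition), compound 2 cannot be told apart from compound 1, as the step shows: a 1.2-fold lower number from compound 1 to compound 2 (0.07 log units; within the scatter). Compound 3 is reported only as a limit, > 500000 nM.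

Compound 4 `C=C1[C@H](n2cnc3c(O)ncnc32)O[C@H](CO)[C@H]1O` differs from compound 2 in one place: hydrogen in place of amino on an aromatic carbon. This puts hydrogen in place of amino on an aromatic carbon, between two ring nitrogen atoms.

Among the measured compounds shown here, no measured step touches this amino group, since all three exchange chloro, hydroxy or methylsulfanyl instead. They therefore bear on it only indirectly, by showing what one exchange on the shared core can do. One step stays within the scatter, while the two large ones, an at least 50-fold higher number from compound 1 to compound 3 (1.69 log units; beyond the scatter) and an at least 58-fold higher number from compound 2 to compound 3 (1.76 log units; beyond the scatter), both go towards a higher number. A moderate move towards weaker inhibition is therefore expected, with much uncertainty: a 5.9-fold higher number from compound 2 to compound 4 (0.77 log units; beyond the scatter).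

For compound 4 the estimated value is 50000 nM, with an expected range of 8000 nM to 300000 nM.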

Compound 4, half-maximal inhibitory concentration: 60000 nM
Estimate against measurement, compound 4: 1.2-fold (0.08 log units) below; the measured number falls inside the stated range.
By their numbers in this assay, from the lowest: compounds 2 and 1 (each within the scatter of the next); then compound 4. At a limit, above all of these: compound 3.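

In this assay, among the compounds shown here, the amino group is changed for the first time, and removing it has a real cost: a 7.1-fold higher number from compound 2 to compound 4 (0.85 log units; beyond the scatter). The earlier steps shown here exchanged only chloro, hydroxy or methylsulfanyl on the shared core, so this shows that the amino group on the aromatic carbon between two ring nitrogen atoms contributes to inhibition, although compound 4 still gives a measurable number without it. Nothing measured among these compounds explains why this change weakens inhibition.

As far as these compounds go, it remains open whether a methyl group or a methylamino group at this place would behave more like amino or more like hydrogen. From the compounds shown here alone, it is also open whether removing amino would cost the same with chloro on the ring, as in compound 1.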